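Methoxy for Trifluoromethyl on Two Related Cores

The source may hold more compounds than are shown below. What is called first, only, known or untested is meant among the compounds shown, and "the series" means these compounds.

Measured compounds:
compound 1, `O=C1C=COC(/C=C/c2ccc(C(F)(F)F)cc2)C1`, 39.6 uM
compound 2, `COc1ccc(/C=C/C2CC(=O)C=CO2)cc1`, 192 uM
compound 3, `O=C1C=CCC(/C=C/c2ccc(C(F)(F)F)cc2)O1`, 44.5 uM

All three were tested in a functional assay on 786-0 cells (Homo sapiens) for inhibition, read by sulforhodamine B assay, with a stated time of 48 h; on this read-out higher numbers stand for weaker inhibition of growth and lower numbers for stronger inhibition of growth. Compound 1 gives 39.6 uM and compound 3, which has the same atoms joined differently, gives 44.5 uM; the difference between the two cores is not broken down here, and the two numbers lie within the scatter of each other. Compound 2 gives 192 uM.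

Compounds 1 and 2 differ in one place: methoxy in place of trifluoromethyl on an aromatic carbon. This change produced a 4.8-fold higher number from compound 1 to compound 2 (0.69 log units; beyond the scatter).

Compound 4, `COc1ccc(/C=C/C2CC=CC(=O)O2)cc1`, has not yet been measured. It differs from compound 3 by the same change, (methoxy in place of trifluoromethyl on an aromatic carbon), at the same place. The change occurs twice among these compounds, once measured and once not. Since the cores of compound 1 and compound 3 give numbers within the scatter of each other, the account expects the change to act alike on both, and estimates a step of a 4.7-fold higher number from compound 3 to compound 4 (0.67 log units; beyond the scatter) from compound 3 to compound 4 in this assay, beside the measured 4.8-fold higher number from compound 1 to compound 2 (0.69 log units; beyond the scatter). On this basis compound 4 is estimated at 210 uM in this assay, expected to lie between 90 uM and 500 uM.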

Compound 4, concentration for growth inhibition (reported as GI): 21.6 uM
For compound 4 the middle estimate is 9.7-fold (0.99 log units) above the measured one, and the stated range ends above it.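

In this assay, methoxy in place of trifluoromethyl on an aromatic carbon gave a 2.1-fold lower number from compound 3 to compound 4 (0.31 log units; beyond the scatter), so on this core the change ran opposite to its direction on the core of compound 1. Set side by side, the two steps differ in direction and lie further apart than two such steps would scatter: the same change on two cores in this assay, a 4.8-fold higher number (0.69 log units; beyond the scatter) from compound 1 to compound 2 and a 2.1-fold lower number (0.31 log units; beyond the scatter) from compound 3 to compound 4, 10-fold (1.00 log units) apart, beyond the scatter of two such steps

The size and direction of this change therefore cannot be carried from one core to the other in this series, even though compound 1 and compound 3 give numbers within the scatter of each other, so closeness between the two trifluoromethyl compounds did not predict how the two methoxy compounds would compare. The two steps do not show why the cores part, and with a single step on each core they say nothing about how the change would act on any further core.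

The compounds shown leave open whether other groups on the same aromatic carbon, such as a chlorine, a hydroxyl or an amine, would side with trifluoromethyl or with methoxy on each core. Whether the reversal would hold on other cells also stays open, as only this one read-out is shown.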